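Series notes: the cap change from compound 2 to compound 4

The source may report more compounds than this note shows. Statements on the series, on what has been measured and on what is new or still open speak of the compounds shown alone.

Compound 1 `CC(C)N(C(=O)CCNC(=O)c1ccc(S(C)(=O)=O)c([N+](=O)[O-])c1)C(C)C`, compound 2 `CC1CCN(C(=O)CCNC(=O)c2ccc(S(C)(=O)=O)c([N+](=O)[O-])c2)CC1` and compound 3 `CS(=O)(=O)c1ccc(C(=O)NCCCC(=O)N2CCCCC2)cc1[N+](=O)[O-]` share one core and differ only in the amide cap. In an assay on isolated protein for inhibition of vitamin D3 receptor (Homo sapiens), read by fluorescence polarization (a higher number here means a weaker inhibitor, a lower number a stronger inhibitor), compound 1 gives only a limit, > 60000 nM. In this assay compound 2 likewise gives only a limit, > 60000 nM. In this assay compound 3 also gives a limit, > 60000 nM. The steps a step that the two limits leave unreadable from compound 1 to compound 2, a step that the two limits leave unreadable from compound 1 to compound 3 and a step that the two limits leave unreadable from compound 2 to compound 3 therefore cannot be sized, because of the limit of > 60000 nM in this assay, at which 3 of the 3 values shown sit. Compound 4 `CS(=O)(=O)c1ccc(C(=O)NCCC(=O)N2CCc3ccccc32)cc1[N+](=O)[O-]` carries 2,3-dihydro-1H-indol-1-yl in place of 4-methylpiperidin-1-yl on a carbonyl carbon. Among the measured compounds shown here, no measured step reads this change, and every cap tried so far sits at the limit, so the change is expected to move compound 4 little. Compound 4 is thus expected to give 80000 nM, within 20000 nM to 300000 nM, most likely again as a limit, an expected step that the limit leaves unreadable from compound 2 to compound 4.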

Compound 4, half-maximal inhibitory concentration: > 60000 nM
Compound 4: no number, only a limit; the forecaster's own chance of this, stated with the estimate: 80%; the middle value lies beyond the limit too.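

In this assay compound 4 gives > 60000 nM, which is a limit and not a number. No step from compound 1 or compound 2 to compound 4 can be read: the limit of > 60000 nM in this assay, at which 4 of the 4 values shown sit.

Going by these compounds, whether any amide cap on the shared core gives a measurable value stays open.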